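A few compounds are considered here, and "the series" means these few. Any claim that something is new, unique, unknown or untested is made for them only; others in the source may bear on it.

Working notes on the series. One core is shared by compound 1, `Nc1nc(N)c2cc(CSC(=S)N3CCN(c4ccccc4)CC3)ccc2n1`, compound 2, `Cc1ccc(N2CCN(C(=S)SCc3ccc4nc(N)nc(N)c4c3)CC2)c(C)c1`, and compound 3, `CC(=O)c1ccc(N2CCN(C(=S)SCc3ccc4nc(N)nc(N)c4c3)CC2)cc1`; they differ only in the aromatic group on the amine nitrogen of the six-membered non-aromatic ring with two nitrogens. In a functional assay on HCT-116 cells (Homo sapiens) for antiproliferative activity, read by MTT assay, with a stated time of 72 h (a higher number here means a weaker inhibitor, a lower number a stronger inhibitor), compound 1 gives 4120 nM, compound 2 gives 4070 nM and compound 3 gives 8260 nM. Compound 2 holds the lowest of the three numbers, yet a 1.0-fold lower number from compound 1 to compound 2 (0.01 log units; within the scatter) leaves that pair unranked, and only a 2.0-fold higher number from compound 2 to compound 3 (0.31 log units; beyond the scatter) sets compound 2 apart from compound 3. The next candidate is compound 4, `Nc1nc(N)c2cc(CSC(=S)N3CCN(c4ccccn4)CC3)ccc2n1`; its change from compound 2 is pyridin-2-yl in place of 2,4-dimethylphenyl on an amine nitrogen in a ring. The measured swaps of this same group bear on it: a 1.0-fold lower number from compound 1 to compound 2 (0.01 log units; within the scatter), a 2.0-fold higher number from compound 2 to compound 3 (0.31 log units; beyond the scatter) and a 2.0-fold higher number from compound 1 to compound 3 (0.30 log units; within the scatter). Exchanging the aromatic group has so far moved the number either not at all or modestly upward, so a small-to-modest shift, or none beyond the scatter, is expected, amounting to a 1.2-fold higher number from compound 2 to compound 4 (0.09 log units; within the scatter). Compound 4 is therefore estimated at 5000 nM, with a range of 2500 nM to 10000 nM.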

Compound 4, half-maximal inhibitory concentration: 5960 nM
The estimate for compound 4 lay 1.2-fold (0.08 log units) below the measured number; low and high end bracket the measured number.
By their numbers in this assay, from the lowest: compounds 2, 1, 4 and 3 (each within the scatter of the next, the first and the last beyond it).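

Going by these compounds alone, compound 4 is the first with a hetero atom in the aromatic ring on the amine nitrogen, and this exchange stays within the scatter against all three groups with a ring of carbon only: phenyl (a 1.4-fold higher number from compound 1 to compound 4 (0.16 log units; within the scatter)), 2,4-dimethylphenyl (a 1.5-fold higher number from compound 2 to compound 4 (0.17 log units; within the scatter)) and 4-acetylphenyl (a 1.4-fold lower number from compound 3 to compound 4 (0.14 log units; within the scatter)). In this assay, a ring nitrogen and a hydrogen-bond acceptor in this group therefore do not separate compound 4 from any other compound, although compound 2 and compound 3 remain apart beyond the scatter. Nothing available explains this result.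

The compounds shown leave open whether pyridin-4-yl would stay within the same range. They also leave open whether a group without an aromatic ring on this nitrogen, such as a cyclohexyl ring or a longer alkyl chain, would move the number further.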